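Removing the long chain from compound 3

The source may report more compounds than this note shows. Statements on the series, on what has been measured and on what is new or still open speak of the compounds shown alone.

Compound 1 `Cc1[nH]c2ccc(Cl)cc2c(=O)c1Cc1ccccc1` measures 2.79 in the first reading
Compound 2 `CCc1c(C)[nH]c2cc(OC)c(Cl)cc2c1=O` measures 2.43 in the same reading
Compound 3 `CCCCCCCCCc1c(C)[nH]c2cc(OC)c(Cl)cc2c1=O` measures 4.74 in the same reading

These three numbers come from a physicochemical assay for lipophilicity, at pH 7.4 (on this read-out higher numbers stand for higher lipophilicity and lower numbers for lower lipophilicity), and compound 3 stands highest among them, with both compound 1 and compound 2 lower by more than the scatter. The next compound, compound 4 `COc1cc2[nH]c(C)c(C)c(=O)c2cc1Cl`, has not yet been measured. The change leading to it is hydrogen in place of octyl on a saturated chain carbon bound to an aromatic carbon and amounts to hydrogen in place of octyl on a saturated chain carbon bound to an aromatic carbon.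

Among the compounds with values here, one measured step bears on this change: a number 2.31 log units higher from compound 2 to compound 3 (beyond the scatter) with heptyl in place of hydrogen. Within the data shown here, compound 1 differs from compound 3 in more than one place and offers no such step. The new change runs the opposite way and removes octyl rather than heptyl, so a large fall of slightly greater size is expected in this assay here. The expected step is a number 2.59 log units lower from compound 3 to compound 4 (beyond the scatter) on this reasoning. Compound 4 is estimated at 2.15 with an expected range from 1.8 to 2.5 for the measurement.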

Compound 4, distribution coefficient: 1.86
Compound 4: the middle estimate sits 0.29 log units above what was measured; the range from low to high includes it.
By their numbers in this assay, from the lowest: compound 4; then compound 2; then compound 1; then compound 3.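

Compound 4 gives the saturated chain carbon bound to an aromatic carbon a series of three groups in this assay: hydrogen, methyl and octyl, with numbers rising in that order and no compound shown going against it. Even the smallest of these changes counts, since hydrogen in place of methyl moves the number beyond the scatter (a number 0.57 log units lower from compound 2 to compound 4 (beyond the scatter)), although most of the range lies in the octyl change (a number 2.88 log units lower from compound 3 to compound 4 (beyond the scatter)). Nothing measured here gives a reason for either step.

As far as these compounds go, whether the rise continues with a chain longer than octyl, and how it runs across chains between methyl and octyl, remains open. So does the effect of an amine or a carboxylic acid on this carbon.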